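Chloro-methylphenyl amide estimated from three measured analogues

The compounds below may be only part of what the source reports. "The series", "measured", "known", "first", "only" and "open" are said of these compounds alone.

Measured so far:
Compound 1, `Cc1ccc(C(=O)NCN2CCC(c3cccc[n+]3[O-])CC2)cc1C`, gives 38 nM in a functional assay on HEK293 cells for agonist activity at D(4) dopamine receptor (Homo sapiens), read by FLIPR; a higher number here means that more compound is needed for the effect, a lower number that less compound is needed.
Compound 2, `Cc1cc(C(=O)NCN2CCC(c3cccc[n+]3[O-])CC2)ccc1F`, gives 50 nM.
Compound 3, `O=C(NCN1CCC(c2cccc[n+]2[O-])CC1)c1cnccc1Cl`, gives 1290 nM.

Compound 3 stands highest of the three numbers in this assay. Its nearest neighbour is compound 2, reached by a 26-fold higher number from compound 2 to compound 3 (1.41 log units; beyond the scatter); the furthest is compound 1, reached by a 34-fold higher number from compound 1 to compound 3 (1.53 log units; beyond the scatter). Both steps are large and beyond the scatter, and both replace a substituted phenyl on the carbonyl carbon with the 4-chloropyridin-3-yl group.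

Compound 4, `Cc1cc(C(=O)NCN2CCC(c3cccc[n+]3[O-])CC2)ccc1Cl`, has not been measured. It differs from compound 3 in one place: 4-chloro-3-methylphenyl in place of 4-chloropyridin-3-yl on a carbonyl carbon. This change runs the two large steps backwards, restoring a substituted phenyl on the carbonyl carbon. Compound 1 and compound 2 show that varying the substituents on that phenyl changes little, as a 1.3-fold higher number from compound 1 to compound 2 (0.12 log units; within the scatter) lies within the scatter. Compound 4 is therefore expected to sit close to compound 1 and compound 2, with a large downward step a 29-fold lower number from compound 3 to compound 4 (1.46 log units; beyond the scatter). The estimate for compound 4 is 45 nM, with a range from 18 nM to 120 nM.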

Compound 4, half-maximal effective concentration: 2460 nM
The estimate for compound 4 lay 55-fold (1.74 log units) below the measured number, outside the stated range (above it).
By their numbers in this assay, from the lowest: compounds 1 and 2 (each within the scatter of the next); then compounds 3 and 4 (each within the scatter of the next).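

In this assay the step of a 1.9-fold higher number from compound 3 to compound 4 (0.28 log units; within the scatter) shows that a substituted phenyl on the carbonyl carbon does not by itself give a low number, since 4-chloro-3-methylphenyl and 4-chloropyridin-3-yl stand within the scatter of each other. The large change instead follows a single substituent on an aromatic carbon, with chloro in place of fluoro giving a 49-fold higher number from compound 2 to compound 4 (1.69 log units; beyond the scatter) and chloro in place of methyl giving a 65-fold higher number from compound 1 to compound 4 (1.81 log units; beyond the scatter) while fluoro in place of methyl had stayed within the scatter. Nothing available here accounts for this sensitivity to chloro.

As far as these compounds go, whether bromo or trifluoromethyl in place of chloro on that aromatic carbon would give a number near compound 1 or near compound 4 remains open. So does whether chloro is equally decisive on a phenyl without the methyl group.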